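Aryl sulfonamide in place of isopropyl: an expected step

The source may hold more compounds than are shown below. What is called first, only, known or untested is meant among the compounds shown, and "the series" means these compounds.

Compound 1 `CC(C)NS(=O)(=O)c1ccc2c(c1)C(n1ccccc1=O)=CC(C)(C)O2`: 76.9%
Compound 2 `CC1(C)C=C(n2ccccc2=O)c2cc(S(=O)(=O)Nc3ccccc3)ccc2O1`: 63.6%; 82.5% (2 entries)

Within the data shown here, in a functional assay on the whole organism (aorta) with Rattus norvegicus as the target (on this read-out lower numbers stand for smaller maximal responses and higher numbers for larger maximal responses), compound 1 gives 76.9%, the only full number of its own there; a further entry for compound 1 carries no single number. Compound 2 gives 63.6%; 82.5% (2 entries) in this assay, and its two entries (the several entries of compound 2 in this assay, 63.6%; 82.5% (2 entries)) show how far repeated measurements of one compound can fall apart. Compound 3 `COc1ccc(NS(=O)(=O)c2ccc3c(c2)C(n2ccccc2=O)=CC(C)(C)O3)cc1` has not yet been measured in this assay. It differs from compound 1 in one place: 4-methoxyphenyl in place of isopropyl on a sulfonamide nitrogen. Among the measured compounds shown here, no measured pair isolates this change, so the size of the step is open. The values of compound 1 and compound 2 both fall in one band, and nothing points to a step beyond the scatter in this assay. Compound 3 is expected to give 72%, within 55% and 90%. The expected step of a number 4.9 percentage points lower from compound 1 to compound 3 (within the scatter) is therefore small, none beyond the scatter.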

Compound 3, largest response reached (Emax), in percent of the reference or control that the assay uses: 77.9%
Compound 3: the middle estimate sits 5.9 percentage points below what was measured; the range from low to high includes it.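

Replacing isopropyl with 4-methoxyphenyl on a sulfonamide nitrogen gives, in this assay, a number 1 percentage points higher from compound 1 to compound 3 (within the scatter), so this change now has a measured pair of its own. The position on the sulfonamide nitrogen therefore takes a six-membered aromatic ring carrying a methoxy group in place of isopropyl with no step beyond the scatter in this read-out. How finely this single pair can be read is limited by the spread seen for one compound on repetition: the several entries of compound 2 in this assay, 63.6%; 82.5% (2 entries)

On these data alone, whether a chain ending in an amine or a carboxylic acid on the same sulfonamide nitrogen would bring a step beyond the scatter remains open. So does the question of whether the sulfonamide hydrogen itself matters, as every compound shown keeps it.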